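Replacing One Aromatic Group on a Shared Chain

A few compounds are considered here, and "the series" means these few. Any claim that something is new, unique, unknown or untested is made for them only; others in the source may bear on it.

Compound 1 `COc1cc(OC)c(OC)cc1/C=C/COC(=O)/C=C/c1ccc(OC)c(OC)c1` was examined in a functional assay on the whole organism (strain Kunming) with Mus musculus as the target, with a stated time of 0.5 h, at a dose of 100 mg/kg by the intraperitoneal route (a higher number here means a weaker effect of the compound at the dose given, a lower number a stronger effect), where compound 1 gives 100%. Compound 2 `COc1cc(OC)c(OC)cc1/C=C/COC(=O)/C=C/c1c(OC)ccc(OC)c1OC` shares the same core and in this assay compound 2 gives 100%. At the digits reported, compound 1 stands level with compound 2, and the two values lie within the usual scatter of each other, so no order between them can be read from these numbers.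

Compound 3 `COc1cc(OC)c(OC)cc1/C=C/COC(=O)/C=C/c1ccccc1Cl` differs from compound 1 in one place: 2-chlorophenyl in place of 3,4-dimethoxyphenyl on a double-bonded chain carbon bound to a double-bonded chain carbon. Among the measured compounds shown here, no step between two measured compounds covers this change, so no measured reference exists for the size of the effect. Both measured compounds return the same reading in this assay, which gives no indication of movement in either direction from such a change.

On this basis, compound 3 is expected to show a reading close to that of compound 1, with the step of a number 5 percentage points lower from compound 1 to compound 3 (within the scatter) estimated to lie within the scatter. For compound 3 the estimated value in this assay is 95%, with a range from 70% to 100%.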

Compound 3, a percentage reported as activity, at one dose (the size of the read-out at that dose, not a potency): 100%
Compound 3: the middle estimate sits 5 percentage points below what was measured; the range from low to high includes it.
By their numbers in this assay, from the lowest: compounds 1, 2 and 3 (each within the scatter of the next).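

Among the compounds shown here, putting 2-chlorophenyl in place of 3,4-dimethoxyphenyl on a double-bonded chain carbon bound to a double-bonded chain carbon gives no change at the digits printed from compound 1 to compound 3 (within the scatter) in this assay, which is the first measured step at this place. The earlier compounds shown here offered no such step, and this one shows that the reading holds when the two methoxy groups are gone, a chlorine is present, and the group has fewer heavy atoms and no hydrogen-bond acceptors. Nothing available explains why the reading stays the same after this exchange.

All three compounds read alike, so the compounds shown do not reveal whether any group at this place can move the reading in this assay at all, and they show no lower reading against which this position could be judged. On these data alone, whether a phenyl ring carrying an amine or a carboxylic acid at this place, or a longer chain in place of the aromatic group, would give a stronger effect at the dose used remains open, as does the effect of changes elsewhere on the shared core.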